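One Side Group Exchanged on Compound 3

The compounds below may be only part of what the source reports. "The series", "measured", "known", "first", "only" and "open" are said of these compounds alone.

In a functional assay on the whole organism for antagonist activity, with Mus musculus as the target, in the maximal electroshock model (on this read-out higher numbers stand for an effect only at larger amounts of compound and lower numbers for an effect already at smaller amounts), compound 3 (`Cn1c(-c2ccccc2)nnc1[S+](C)[O-]`) reads > 100 mg/kg as a limit and not a number. Compound 1 (`Cn1c(-c2cccc(F)c2)nnc1S(C)(=O)=O`) reads > 200 mg/kg as a limit too. Compound 2 (`Cn1c(-c2cccs2)nnc1S(C)(=O)=O`) reads > 200 mg/kg as a further limit. Among the compounds with values here, no measured compound therefore gives a true number, and no measured step guides the forecast. Compound 4 (`CCSc1nnc(-c2ccccc2)n1C`) carries ethylsulfanyl on the shared core, and the change is a group of 3 heavy atoms (2 carbon, 1 sulfur; no ring) in place of a group of 3 heavy atoms (1 carbon, 1 oxygen, 1 sulfur; no ring), on an aromatic carbon in the words of the count. A modest move toward smaller doses in this assay is expected, though this is a tentative call, and the estimated step is a number no higher from compound 3 to compound 4 (the limit leaves the size open) on that view. For compound 4 the expected value is 100 mg/kg within an estimated range of 30 mg/kg to 300 mg/kg in this wide forecast.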

Compound 4, dose for half-maximal effect: > 200 mg/kg
Compound 4 gave a limit, no number; the forecaster's own chance of this, stated with the estimate: 40%; middle value at least 2.0-fold (0.30 log units) from the limit.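

Within the data shown here, compound 3 and compound 4 each read as a limit and not a number in this assay, and no step between them can be read. The compounds shown leave open at what dose any of them reaches half-maximal effect.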